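The compounds below may be only part of what the source reports. "The series", "measured", "known", "first", "only" and "open" are said of these compounds alone.

Compound 3 `Cc1cc2c(cc1Cc1ccc(C(=O)NCc3ccc(CN)cc3)o1)C(C)(C)CCC2(C)C` sits in the middle of the three measured numbers in an assay on isolated protein for binding affinity to Gonadotropin-releasing hormone receptor (Homo sapiens); a lower number here means a stronger inhibitor, a higher number a weaker inhibitor: compound 3 gives 140 nM, compound 2 `Cc1ccc(CNC(=O)c2ccc(Cc3cc4c(cc3C)C(C)(C)CCC4(C)C)o2)cc1` gives 83 nM and compound 1 `Cc1cc2c(cc1Cc1ccc(C(=O)NC[C@H]3CC[C@H](C(=O)O)CC3)o1)C(C)(C)CCC2(C)C` gives 250 nM, and both steps to compound 3 lie within the scatter, so no order among the three can be read off. Compound 4 `Cc1cc2c(cc1Cc1ccc(C(=O)NCC3CCCC(CN)C3)o1)C(C)(C)CCC2(C)C` differs from compound 3 by 3-(aminomethyl)cyclohexyl in place of 4-(aminomethyl)phenyl on a saturated chain carbon bound to an amide-type nitrogen.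

Among the compounds with values here, the only measured steps that touch the saturated-ring question are a 3.0-fold lower number from compound 1 to compound 2 (0.48 log units; beyond the scatter) and a 1.8-fold lower number from compound 1 to compound 3 (0.25 log units; within the scatter); both go from a saturated ring to an aromatic one while also changing the polar group, so they bear on the present change only loosely, and in the opposite direction. The step of a 1.7-fold higher number from compound 2 to compound 3 (0.23 log units; within the scatter) says nothing about the ring itself. On that basis a modest rise in this assay is expected for compound 4, about a 1.8-fold higher number from compound 3 to compound 4 (0.25 log units; within the scatter), with a clear chance of no change beyond the scatter. Compound 4 is therefore estimated at 250 nM in this assay, within 100 nM to 650 nM.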

Compound 4, inhibition constant: 174 nM
Estimate against measurement, compound 4: 1.4-fold (0.16 log units) above; the measured number falls inside the stated range.
By their numbers in this assay, from the lowest: compounds 2, 3, 4 and 1 (each within the scatter of the next, the first and the last beyond it).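

In this assay, 3-(aminomethyl)cyclohexyl in place of 4-(aminomethyl)phenyl on a saturated chain carbon bound to an amide-type nitrogen gives (a 1.2-fold higher number from compound 3 to compound 4 (0.09 log units; within the scatter)), so an aromatic ring is not needed here for a number in this range, at least with the aminomethyl group retained. Against 4-methylphenyl the same group gives a modest step beyond the scatter (a 2.1-fold higher number from compound 2 to compound 4 (0.32 log units; beyond the scatter)), whereas the comparison with 4-carboxycyclohexyl stays within it (a 1.4-fold lower number from compound 1 to compound 4 (0.16 log units; within the scatter)). No measurement on hand accounts for any of these steps.

The step from compound 3 to compound 4 changes the ring type and the substitution pattern together, and 3-(aminomethyl)phenyl or 4-(aminomethyl)cyclohexyl would separate the two. Also open, as far as these compounds go, is how the number responds to 2-aminoethyl in place of aminomethyl on either ring.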